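A few compounds are considered here, and "the series" means these few. Any claim that something is new, unique, unknown or untested is made for them only; others in the source may bear on it.

Measured compounds:
compound 1 `CCOc1cc(C(=O)N(C)C)ccc1Nc1nc(O[C@H]2CC[C@@](C)(O)CC2)c2cc[nH]c2n1` gives 26 nM in a functional assay on CAL-51 cells (Homo sapiens) for antiproliferative activity, read by luminescence and CellTiter-Glo, with a stated time of 3 days; a lower number here means a stronger inhibitor, a higher number a weaker inhibitor;
compound 2 `COc1cc(C(=O)N(C)C)ccc1Nc1nc(OC2COC2)c2cc[nH]c2n1` gives 1960 nM;
compound 3 `COc1cc(N2CCN(C3COC3)CC2)ccc1Nc1nc(O[C@H]2CCOC(C)(C)C2)c2cc[nH]c2n1` gives 84 nM.

Of these three, compound 2 has the highest number, so it is the weakest inhibitor of the set; its gaps to compound 3 and to compound 1 are both beyond the usual scatter of this assay, so the order is real. Compound 4 `COc1cc(C(=O)N(C)C)ccc1Nc1nc(OC2CCOCC2)c2cc[nH]c2n1` has not yet been measured. It keeps the whole core and the amide-bearing ring of compound 2 and differs in a single place: oxan-4-yl in place of oxetan-3-yl on an oxygen on an aromatic ring. For the measured compounds named here, no measured pair differs in exactly this way, so there is no directly comparable step. Still, the two compounds with far lower numbers, compound 1 and compound 3, both carry six-membered rings at that oxygen, which suggests a move toward stronger inhibition. The step from compound 2 to compound 4 is expected to be an 11-fold lower number from compound 2 to compound 4 (1.04 log units; beyond the scatter), beyond the scatter, toward a lower number. Compound 4 is therefore estimated at 180 nM, with a plausible range from 45 nM to 700 nM.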

Compound 4, half-maximal inhibitory concentration: 198 nM
Beside the measured number, compound 4's estimate is 1.1-fold (0.04 log units) below it; the measured number falls inside the stated range.
By their numbers in this assay, from the lowest: compound 1; then compound 3; then compound 4; then compound 2.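

In this assay, replacing oxetan-3-yl with oxan-4-yl on the oxygen gives a 9.9-fold lower number from compound 2 to compound 4 (1.00 log units; beyond the scatter) as a step beyond the scatter. For the compounds shown here, this is the first pair here that differs in one place only, so it shows that this ring alone can shift the number, with the core and the amide-bearing ring unchanged. Nothing available explains why the six-membered ring gives the lower number.

With only these two rings compared directly, the compounds shown cannot separate the effect of ring size from that of the ring oxygen's location, nor establish a trend. A piperidin-4-yl ring, with an amine nitrogen in place of the ring oxygen, or an open 2-methoxyethyl chain on the same oxygen would test how much depends on the ring and its oxygen.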